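Phenyl to Chloro: Two Readings and One Expectation

The source may report more compounds than this note shows. Statements on the series, on what has been measured and on what is new or still open speak of the compounds shown alone.

Compound 1 `O=C(/C=C/c1ccc2c(c1)B(O)OC2)c1ccc(-c2ccccc2)cc1`: 20700 nM
Compound 2 `Cn1cccc1C(=O)/C=C/c1ccc2c(c1)B(O)OC2`: > 100000 nM

Both measured compounds were run in a toxicity assay on MCF-10A cells (Homo sapiens) for cytotoxicity, read by MTT assay, with a stated time of 48 h; a lower number here means a stronger inhibitor, a higher number a weaker inhibitor. Going by the values given here, compound 1 gives 20700 nM, the only definite number among the two. For compound 2 the assay reports a limit, > 100000 nM, and not a number. Put differently, one of the two values sits at the limit of > 100000 nM in this assay, at which 1 of the 2 values shown sits.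

Compound 3 `O=C(/C=C/c1ccc2c(c1)B(O)OC2)c1ccc(Cl)cc1` has not yet been tested. It differs from compound 1 in a single spot: chloro in place of phenyl on an aromatic carbon. The change sits on an aromatic carbon of a six-membered aromatic ring of carbon only, para to a large group. Among the compounds with values here, no measured pair here shares this change, so there is no measured step to lean on.

The step from compound 1 to compound 3 is expected to be a 2.4-fold higher number from compound 1 to compound 3 (0.38 log units; beyond the scatter), toward weaker inhibition, but of moderate size. Compound 3 is expected to give 50000 nM, with a range from 15000 nM to 150000 nM.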

Compound 3, half-maximal inhibitory concentration: 12100 nM
The estimate for compound 3 lay 4.1-fold (0.62 log units) above the measured number; measured number outside the range, below it.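

In this assay, chloro in place of phenyl on an aromatic carbon, para to a large group, gives a 1.7-fold lower number from compound 1 to compound 3 (0.23 log units; within the scatter), so a whole six-membered ring can be replaced here by a single atom without a real shift in the reading. On the carbonyl carbon, 4-chlorophenyl in place of 1-methyl-1H-pyrrol-2-yl gives an at least 8.2-fold lower number from compound 2 to compound 3 (0.91 log units; beyond the scatter), a step that, unlike the first, lies beyond the scatter. That second step rests on a limit for compound 2 and not on a number: the limit of > 100000 nM in this assay, at which 1 of the 3 values shown sits.

From the compounds shown here alone, what an amine or a carboxylic acid would give at the position that holds phenyl in compound 1 stays open. With only phenyl and chloro compared there, the compounds shown cannot tell whether the reading stays level for other groups at this spot.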